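A Change of Amine on the Thiocarbonyl Carbon

A few compounds are considered here, and "the series" means these few. Any claim that something is new, unique, unknown or untested is made for them only; others in the source may bear on it.

Compound 1, `O=c1cc(CSC(=S)N2CCCCC2)oc2cc(Cl)ccc12`, gives 2500 nM in a functional assay on SW480 cells (Homo sapiens) for antiproliferative activity, read by MTT assay, with a stated time of 72 h; a lower number here means a stronger inhibitor, a higher number a weaker inhibitor. Compound 2, `O=c1cc(CSC(=S)N2CCCC2)oc2ccccc12`, gives 23400 nM in this assay. Compound 3, `O=c1cc(CSC(=S)N2CCCC2)oc2cc(Cl)ccc12`, reaches in this assay only the limit > 25000 nM.

Compound 3 therefore stands at the edge of this assay with no number of its own, while compounds 1 and 2 each give one. Compound 4, `CC(C)N(C(=S)SCc1cc(=O)c2ccc(Cl)cc2o1)C(C)C`, differs from compound 3 in one place: diisopropylamino in place of pyrrolidin-1-yl on a thiocarbonyl carbon. The measured step that bears on this site is an at least 10-fold higher number from compound 1 to compound 3 (1.00 log units; beyond the scatter), which shows that the amine on the thiocarbonyl carbon matters and that pyrrolidin-1-yl gave the weaker compound. Because of the limit of > 25000 nM in this assay, at which 1 of the 3 values shown sits, the size of that step is known only as a floor. The other step, an at least 1.0-fold higher number from compound 2 to compound 3 (0.02 log units; that floor lies within the scatter), concerns the chloro and not this site. No acyclic amine has been measured here, so the direction is inferred only from the one departure from pyrrolidin-1-yl, which lowered the number. Compound 4 is thus expected to show an at least 3.1-fold lower number from compound 3 to compound 4 (0.49 log units; beyond the scatter), toward lower numbers. Compound 4 is estimated at 8000 nM, between 2000 nM and 25000 nM.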

Compound 4, half-maximal inhibitory concentration: > 25000 nM
Compound 4: a limit, no number; the forecaster's own chance of this, stated with the estimate: 35%; at least 3.1-fold (0.49 log units) between middle value and limit.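

In this assay compound 4, like compound 3, reaches only a limit, so replacing pyrrolidin-1-yl with the acyclic diisopropylamino group gave no measurable value. The change from piperidin-1-yl to diisopropylamino gives an at least 10-fold higher number from compound 1 to compound 4 (1.00 log units; beyond the scatter), so among the three chloro compounds, two amines on the thiocarbonyl carbon now fall short of piperidin-1-yl, where before there was only one. The step between compound 3 and compound 4 cannot be read, and the order of these two amines stays unknown: the limit of > 25000 nM in this assay, at which 2 of the 4 values shown sit.

Open, from the compounds shown here alone, is how morpholin-4-yl, azepan-1-yl or dimethylamino on the thiocarbonyl carbon would compare with piperidin-1-yl. Also open, going by these compounds, is how piperidin-1-yl behaves with hydrogen in place of chloro on the aromatic carbon.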